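The source may report more compounds than this note shows. Statements on the series, on what has been measured and on what is new or still open speak of the compounds shown alone.

Working notes on the series. Compound 3 `COc1cc(Cl)cc(-c2nn(-c3cccc(NC(=O)Nc4ccc(Cl)c(C(F)(F)F)c4)c3)cc2-c2ccncc2)c1` is a urea bearing a 4-chloro-3-(trifluoromethyl)phenyl group; in a functional assay on MOLT-4 cells (Homo sapiens) for inhibition, read by sulforhodamine B assay, with a stated time of 48 h, tested at 10 uM (a higher number here means a weaker effect of the compound at the concentration tested, a lower number a stronger effect), compound 3 gives -9.68%. Among the three numbers recorded compound 3 stands second highest: the nearest is compound 2 `O=C(Nc1cccc(-n2cc(-c3ccncc3)c(-c3cc(O)cc(Cl)c3)n2)c1)Nc1ccc(Cl)c(Cl)c1`, a urea with a 3,4-dichlorophenyl group and a hydroxy in place of the methoxy, which gives -27.1%, and the furthest is compound 1 `COc1cc(Cl)cc(-c2nn(-c3cccc(NC(=O)c4ccc(Cl)c(Cl)c4)c3)cc2-c2ccncc2)c1`, the amide with the 3,4-dichlorophenyl group, which gives 54.9%. Going by the values given here, the one measured step, a number 64.6 percentage points lower from compound 1 to compound 3 (beyond the scatter), moves from amide to urea and swaps the aryl group at once, so it does not isolate the change now in question.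

Compound 4 `COc1cc(Cl)cc(-c2nn(-c3cccc(NC(=O)Nc4ccc(Cl)c(Cl)c4)c3)cc2-c2ccncc2)c1` differs from compound 3 by chloro in place of trifluoromethyl on an aromatic carbon. Among the compounds with values here, no measured step separates this change alone. Compound 2 carries the same 3,4-dichlorophenyl urea as compound 4 and sits below compound 3, which points toward a lower number, but the methoxy to hydroxy difference between compound 2 and compound 4 is unmeasured. The step expected in this assay is therefore small, a number 8.3 percentage points lower from compound 3 to compound 4 (within the scatter), probably downward but possibly within the scatter. Compound 4 is estimated at -18%, in a range from -42% to 8%.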

Compound 4, a percentage reported as activity, at one concentration (the size of the read-out at that concentration, not a potency): -16.1%
Compound 4: the middle estimate sits 1.9 percentage points below what was measured; the range from low to high includes it.
By their numbers in this assay, from the lowest: compound 2; then compounds 4 and 3 (each within the scatter of the next); then compound 1.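

In this assay, a number 6.4 percentage points lower from compound 3 to compound 4 (within the scatter), so at this place on the aryl ring, ortho to a chloro group on the urea series, chloro and trifluoromethyl cannot be told apart. With that swap unresolved, the aryl group is held constant in a cleaner reading of the linker: a number 71 percentage points lower from compound 1 to compound 4 (beyond the scatter), and this large step, with (3,4-dichlorophenyl)amino in place of 3,4-dichlorophenyl on a carbonyl carbon, isolates the amide-to-urea change that the earlier step mixed with an aryl swap. The hydroxy and methoxy pair can now be read as well, a modest step beyond the scatter with methyl in place of hydrogen on the oxygen: a number 11 percentage points higher from compound 2 to compound 4 (beyond the scatter).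

No measurement at hand bears on why any of these steps arises. Open, as far as these compounds go, are whether a smaller or different group at this place, such as a methyl, a nitrile or an amine, would also leave the read-out unchanged, and whether chloro and trifluoromethyl would stay indistinguishable on the amide series or alongside the hydroxy group.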